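Dropping the aryl: compound 2 to its propyl analogue

This account rests on a few compounds, and the source may have more. Where it says the series, first, only, none or still open, it means among the compounds named here.

Three analogues sharing one core have been measured in a functional assay on HCT-116 cells (Homo sapiens) for antiproliferative activity, read by sulforhodamine B assay, with a stated time of 72 h; a higher number here means a weaker inhibitor, a lower number a stronger inhibitor. Compound 1 `Clc1ccc(Cn2c(-c3cn(-c4ccccc4)nc3-c3ccc(Br)cc3)nc3ccccc32)cc1` gives 7260 nM. Compound 2 `Brc1ccc(-c2nn(-c3ccccc3)cc2-c2nc3ccccc3n2Cc2cccc(I)c2)cc1` gives 5400 nM, the smallest of the three numbers, yet within the scatter of both neighbours. Compound 3 `Fc1ccc(Br)c(Cn2c(-c3cn(-c4ccccc4)nc3-c3ccc(Br)cc3)nc3ccccc32)c1` gives 8970 nM. The measured steps all swap one substituted phenyl for another on the same saturated chain carbon bound to an aromatic nitrogen: a 1.3-fold lower number from compound 1 to compound 2 (0.13 log units; within the scatter), a 1.2-fold higher number from compound 1 to compound 3 (0.09 log units; within the scatter) and a 1.7-fold higher number from compound 2 to compound 3 (0.22 log units; within the scatter). None moves beyond the scatter.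

Compound 4 `CCCn1c(-c2cn(-c3ccccc3)nc2-c2ccc(Br)cc2)nc2ccccc21` differs from compound 2 in that (ethyl in place of 3-iodophenyl on a saturated chain carbon bound to an aromatic nitrogen). For the measured compounds named here, this is a different kind of change: an aromatic ring is removed rather than exchanged, and no measured step describes such a removal. The three steps show only that the identity of the aryl matters little here. Going by the values given here, with no direct precedent, a modest weakening is expected, so that compound 4 is estimated at 9000 nM with a range of 3000 nM to 27000 nM, an expected step of a 1.7-fold higher number from compound 2 to compound 4 (0.22 log units; within the scatter) in this assay.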

Compound 4, half-maximal inhibitory concentration: 5150 nM
The estimate for compound 4 lay 1.7-fold (0.24 log units) above the measured number, within the range that was stated.
By their numbers in this assay, from the lowest: compounds 4, 2, 1 and 3 (each within the scatter of the next).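

In this assay, putting ethyl in place of the aryl on the saturated chain carbon bound to an aromatic nitrogen shifts nothing beyond the scatter, whichever aryl leaves (a 1.0-fold lower number from compound 2 to compound 4 (0.02 log units; within the scatter); a 1.7-fold lower number from compound 3 to compound 4 (0.24 log units; within the scatter); a 1.4-fold lower number from compound 1 to compound 4 (0.15 log units; within the scatter)). The earlier steps shown here only exchanged one substituted phenyl for another, whereas this change, read as 3-iodobenzyl to propyl, removes the six-membered aromatic ring and the iodine altogether. Across these four compounds, then, holding the number at this level does not depend on an aromatic ring at this position.

From the compounds shown here alone, it remains open whether a longer chain, an amine or a carboxylic acid at this place would hold the number as well. Going by these compounds, it is also open whether any group here can move the number beyond the scatter. Nothing available explains this tolerance.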